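Three compounds tolerated at the limit; a pyridine analogue awaits

The source may report more compounds than this note shows. Statements on the series, on what has been measured and on what is new or still open speak of the compounds shown alone.

The series shares one core, shown in compound 1 `O=c1c(C2=CS(=O)(=O)c3cc(F)ccc3N2)c(O)c2cc(F)ccc2n1Cc1ccc(F)cc1`, compound 2 `Cc1ccc2c(c1)c(O)c(C1=CS(=O)(=O)c3cc(NS(C)(=O)=O)ccc3N1)c(=O)n2Cc1ccc(F)cc1` and compound 3 `CS(=O)(=O)Nc1ccc2c(c1)S(=O)(=O)C=C(c1c(O)c3cc(F)ccc3n(Cc3ccc(F)c(Cl)c3)c1=O)N2`, and all three were run in an ADME assay on 2209-23 cells (Homo sapiens) for cytotoxicity, read by WST assay; a higher number here means that more compound is tolerated, a lower number that less compound is tolerated. In this assay compound 1 reaches only the limit of > 50000 nM. Compound 2 likewise gives no number but the limit of > 50000 nM. Compound 3, too, stops at the limit of > 50000 nM. Compound 3 therefore stands where every measured member of the set stands, at the limit of > 50000 nM in this assay, at which 3 of the 3 values shown sit, and the three values show no order among themselves, since none of them is a number.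

Compound 4 `CS(=O)(=O)Nc1ccc2c(c1)S(=O)(=O)C=C(c1c(O)c3cc(F)ccc3n(Cc3ccncc3)c1=O)N2` has not yet been measured in this assay. It differs from compound 3 in one place: pyridin-4-yl in place of 3-chloro-4-fluorophenyl on a saturated chain carbon bound to an aromatic nitrogen, that is, 3-chloro-4-fluorobenzyl becomes (pyridin-4-yl)methyl on the saturated chain carbon bound to the aromatic nitrogen. Going by the values given here, no step between measured compounds is available for this kind of change, so the expectation rests only on the three limits already seen. Given that compound 3 sits at the limit of > 50000 nM in this assay, at which 3 of the 3 values shown sit, compound 4 is expected to show no step beyond the scatter, a step that the limit leaves unreadable from compound 3 to compound 4. Compound 4 is estimated at 60000 nM, with a range from 30000 nM to 150000 nM, and most likely reported again as a limit.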

Compound 4, half-maximal cytotoxic concentration: > 50000 nM
Compound 4: only a limit was reported; the forecaster's own chance of this, stated with the estimate: 85%; the middle value is on the limit's open side.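

In this assay compound 4 gives only a limit, > 50000 nM. Going by these compounds alone, compound 3 also stands at a limit, so no step between compound 3 and compound 4 can be read. The compounds shown leave open whether any member of this series would give a readable half-maximal cytotoxic concentration, and therefore how pyridin-4-yl compares with 3-chloro-4-fluorophenyl.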